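One Changed Ring Stereocentre on a Weakly Active Compound

The compounds below may be only part of what the source reports. "The series", "measured", "known", "first", "only" and "open" are said of these compounds alone.

Compound 1 (`CCCCCCCn1cc(COC[C@@H]2OC[C@H](N)[C@@H]2O)nn1`) gives > 128000 nM in a functional assay on MGC-803 cells (Homo sapiens) for antiproliferative activity, read by MTT assay, with a stated time of 48 h (a higher number here means a weaker inhibitor, a lower number a stronger inhibitor), and this is a limit of the assay, not a number. Its position therefore rests only on (the limit of > 128000 nM in this assay, at which 1 of the 3 values shown sits).

Two relatives with longer chains give numbers: compound 2 (`CCCCCCCCn1cc(COC[C@@H]2OC[C@H](N)[C@@H]2O)nn1`) gives 70400 nM, and compound 3 (`CCCCCCCCCCCCn1cc(COC[C@@H]2OC[C@H](N)[C@@H]2O)nn1`) gives 21400 nM. The chain changes give an at least 1.8-fold lower number from compound 1 to compound 2 (0.25 log units; that floor lies within the scatter), then an at least 5.9-fold lower number from compound 1 to compound 3 (0.77 log units; beyond the scatter), and a 3.3-fold lower number from compound 2 to compound 3 (0.52 log units; beyond the scatter).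

Compound 4 (`CCCCCCCn1cc(COC[C@@H]2OC[C@H](N)[C@H]2O)nn1`) keeps the chain of compound 1 and differs elsewhere: the two compounds have the same atoms and bonds and differ only in configuration as drawn: 1 of 3 stereo elements differ; a stereocentre at a saturated ring carbon is drawn S in compound 1 and R in compound 4. The two compounds have the same atoms and bonds, and only the configuration drawn at a saturated ring carbon differs.

All three measured steps alter the chain, and none alters configuration, so they give no size for this change. Going by the values given here, they show only that chain changes in this small set can move the number. The starting point is also only a limit, so no step beyond the scatter is expected in this assay, and a change in either direction remains possible.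

The estimated step is a number no higher from compound 1 to compound 4 (the limit leaves the size open).

For compound 4 the expected value is 128000 nM, with an estimated range from 50000 nM to 260000 nM.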

Compound 4, half-maximal inhibitory concentration: > 128000 nM
Compound 4: a limit, no number; the forecaster's own chance of this, stated with the estimate: 60%; the middle value sits exactly at the limit.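

Compound 1 and compound 4 both stop at a limit of the assay rather than giving a number, so no step between them can be read: the limit of > 128000 nM in this assay, at which 2 of the 4 values shown sit.

The compounds shown leave open whether the configuration drawn at the saturated ring carbon changes the result in this assay at all, and in which direction.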